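Bromo in place of methoxy: expected cytotoxicity of compound 4

The source may report more compounds than this note shows. Statements on the series, on what has been measured and on what is new or still open speak of the compounds shown alone.

Measured so far in an ADME assay on MT4 cells (Homo sapiens) for cytotoxicity, read by MTT assay, with a stated time of 4 days; on this read-out higher numbers stand for lower toxicity in this test and lower numbers for higher toxicity in this test:
Compound 1 `COc1cc2cc(C#N)ccc2cc1Oc1ccnc(Nc2ccc(C#N)cc2)n1` gives > 318000 nM, a limit of the test rather than a number.
Compound 2 `COc1cc2cc(C#N)ccc2c(OC)c1Oc1ccnc(Nc2ccc(C#N)cc2)n1` gives > 118000 nM, also a limit.
Compound 3 `COc1cc2cc(C#N)ccc2c(Cl)c1Oc1ccnc(Nc2ccc(C#N)cc2)n1` gives > 190000 nM, also a limit.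

Compound 1 therefore stands only at a limit in this assay, as do both other compounds, so no exact number is known for any of them. The change to compound 4 `N#Cc1ccc(Nc2nccc(Oc3cc4ccc(C#N)cc4cc3Br)n2)cc1` is bromo in place of methoxy on an aromatic carbon. The steps a step that the two limits leave unreadable from compound 1 to compound 2, a step that the two limits leave unreadable from compound 1 to compound 3 and a step that the two limits leave unreadable from compound 2 to compound 3 each swap a small group at the same carbon and stay unreadable because of the limit of > 118000 nM in this assay, at which 1 of the 3 values shown sits, the limit of > 190000 nM in this assay, at which 1 of the 3 values shown sits, and the limit of > 318000 nM in this assay, at which 1 of the 3 values shown sits, are all limits. No step beyond the scatter is expected here. Compound 4 is expected at 200000 nM, between 80000 nM and 400000 nM, most likely again reported only as a limit. The expected step of an at least 1.5-fold lower number from compound 1 to compound 4 (0.20 log units; that floor lies within the scatter) lies within the scatter.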

Compound 4, half-maximal cytotoxic concentration: > 56500 nM
Compound 4 ended at the assay's limit (the forecaster's own chance of this, stated with the estimate: 85%); the middle value does not contradict the limit.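

For the compounds shown here, compound 1 and compound 4 are both reported only as limits, so no step between them can be read. The compounds shown leave open whether bromo in place of methoxy changes cytotoxicity at all.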